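A few compounds are considered here, and "the series" means these few. Any claim that something is new, unique, unknown or untested is made for them only; others in the source may bear on it.

Compound 2 `O=C(O)c1ccc2noc(-c3ccc(Oc4ccccn4)cc3)c2c1` gives the weaker of the two results seen so far. In an assay for inhibition of inositol hexakisphosphate kinase 3 (Homo sapiens), read by colorimetric assay, coupled enzyme assay and malachite green, with a stated time of 120 min, in the presence of a further agent that is not named here (a higher number here means a weaker inhibitor, a lower number a stronger inhibitor), compound 2 gives 2060 nM, while compound 1 `O=C(O)c1ccc2noc(-c3ccc(-c4ccncc4)cc3)c2c1` gives 670 nM. For the measured compounds named here, the only step between measured compounds, a 3.1-fold higher number from compound 1 to compound 2 (0.49 log units; beyond the scatter), concerns a different change from the one now in question, so it sets the scale of what a single change has done here without pointing in a direction for the next one. Compound 3 `O=C(O)c1ccc2noc(-c3ccc(Oc4ncc(Cl)cc4Cl)cc3)c2c1` differs from compound 2 in one place: 3,5-dichloropyridin-2-yl in place of pyridin-2-yl on an oxygen on an aromatic ring. Going by the values given here, no measured pair shows what the two chlorine atoms on this ring do, and the data hold nothing that would favour a stronger or a weaker result. Given that the one known step was modest, the expected movement, a 1.4-fold lower number from compound 2 to compound 3 (0.14 log units; within the scatter), is small and is expected to stay within the scatter, with a wide range to allow for either direction. Compound 3 is therefore estimated at 1500 nM in this assay, with a range from 500 nM to 5000 nM.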

Compound 3, half-maximal inhibitory concentration: 2250 nM
Compound 3: the middle estimate sits 1.5-fold (0.18 log units) below what was measured, and the stated range covers the measured number.
By their numbers in this assay, from the lowest: compound 1; then compounds 2 and 3 (each within the scatter of the next).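

In this assay, placing two chlorine atoms on the ring attached to the oxygen gives a 1.1-fold higher number from compound 2 to compound 3 (0.04 log units; within the scatter), so 3,5-dichloropyridin-2-yl and pyridin-2-yl cannot be told apart at this place, even though the new group is larger by its two chlorine atoms. The step of a 3.4-fold higher number from compound 1 to compound 3 (0.53 log units; beyond the scatter) is beyond the scatter, so compound 3, like compound 2 before it, has a higher number than compound 1, with or without the chlorine atoms. The data give no reason for either step.

The compounds shown leave open whether this flat result holds for other groups on the same ring, such as an amine or a methoxy group, and whether a single chlorine atom would behave as the pair does. They also cannot separate the two differences from compound 1, the oxygen link and the change from pyridin-4-yl to a pyridin-2-yl ring, which a (pyridin-4-yl)oxy group would begin to pull apart.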